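Replacing 3-chlorophenyl with 4-cyanophenyl on the shared core

The compounds below may be only part of what the source reports. "The series", "measured", "known", "first", "only" and "open" are said of these compounds alone.

Measured compounds:
compound 1, `C=CC(=O)N1C(=O)CC(c2cccc(Cl)c2)Sc2ccccc21`: 31700 nM
compound 2, `C=CC(=O)N1C(=O)CC(C)Sc2ccccc21`: 227000 nM

In a functional assay on NB-4 cells (Homo sapiens) for cytotoxicity, read by CCK-8 assay, with a stated time of 24 h (on this read-out lower numbers stand for stronger inhibition and higher numbers for weaker inhibition), compound 1 gives 31700 nM, the lowest of the two numbers recorded. Among the compounds with values here, compound 2 is the only neighbour, and in this assay compound 2 gives 227000 nM. Within the data shown here, the one step between measured compounds runs a 7.2-fold higher number from compound 1 to compound 2 (0.85 log units; beyond the scatter), so removing the aromatic ring from that position costs a clear but modest amount of potency.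

Compound 3, `C=CC(=O)N1C(=O)CC(c2ccc(C#N)cc2)Sc2ccccc21`, keeps the aromatic ring at that position and changes only its substituent: 4-cyanophenyl in place of 3-chlorophenyl on a saturated ring carbon. The measured step from compound 1 to compound 2 bears on it only loosely, since that step removed the whole ring, whereas here one substituted phenyl replaces another. Among the measured compounds shown here, no measured pair shows what a change of the substituent on the ring does, so the step in this assay is expected to stay within the scatter, with no direction claimed. Compound 3 is therefore estimated at 40000 nM, with a range from 15000 nM to 110000 nM, which means an expected step of a 1.3-fold higher number from compound 1 to compound 3 (0.10 log units; within the scatter).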

Compound 3, half-maximal inhibitory concentration: 62400 nM
Compound 3: middle estimate off by 1.6-fold (0.19 log units), on the low side; the range from low to high includes it.
By their numbers in this assay, from the lowest: compounds 1 and 3 (each within the scatter of the next); then compound 2.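

In this assay, within the data shown here, the result gives the first view of a change of substituent on the aromatic ring at this position: 4-cyanophenyl in place of 3-chlorophenyl gives a 2.0-fold higher number from compound 1 to compound 3 (0.29 log units; within the scatter) and so leaves the two substituted phenyl groups unseparated, even though 4-cyanophenyl carries a hydrogen-bond acceptor that 3-chlorophenyl lacks. Against the methyl compound, the new aromatic group gives a 3.6-fold lower number from compound 2 to compound 3 (0.56 log units; beyond the scatter) in the same assay, so the advantage over methyl, previously seen for 3-chlorophenyl alone, now holds for two differently substituted phenyl groups, though by a modest margin in each case. No supporting data explain why these numbers fall as they do.

The compounds shown leave open how an unsubstituted phenyl group, or a phenyl ring carrying an amine or a carboxylic acid, would compare with compound 1 and compound 3 at this position. They also leave open how a longer chain in place of methyl would compare with compound 2, and whether the substituent itself or its place on the phenyl ring matters, since both differ together between compound 1 and compound 3.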